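This account rests on a few compounds, and the source may have more. Where it says the series, first, only, none or still open, it means among the compounds named here.

Measured compounds in a functional assay on HeLa cells (Homo sapiens) for inhibition, read by cell counting, with a stated time of 4 days; a lower number here means a stronger inhibitor, a higher number a weaker inhibitor:
- compound 1 `Nc1cccc(-c2cn3nc(-c4cccs4)sc3n2)c1`; in this assay compound 1 gives > 250000 nM, a limit of the assay and not a number.
- compound 2 `Nc1cccc(-c2cn3nc(-c4ccccc4)sc3n2)c1`; in this assay compound 2 gives 26000 nM.

For the measured compounds named here, compound 2 holds the only real number in this assay so far; the other entry for the series is a limit. Going by the values given here, the one measured step, an at least 9.6-fold lower number from compound 1 to compound 2 (0.98 log units; beyond the scatter), can only be read as a lower bound on its size since compound 1 sits at the limit of > 250000 nM in this assay, at which 1 of the 2 values shown sits.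

Compound 3 `Cc1ccc(-c2nn3cc(-c4cccc(N)c4)nc3s2)cc1` differs from compound 2 by methyl in place of hydrogen on an aromatic carbon. Among the compounds with values here, no measured step covers this kind of change: the step from compound 1 to compound 2 swaps one aromatic ring for another, and nothing measured adds a small group to the phenyl. The expectation therefore rests on compound 2 alone, and the change is taken to be too small to move the number beyond the usual scatter in either direction. Compound 3 is estimated at 20000 nM in this assay, with a range of 7000 nM to 60000 nM. That estimate means a step of a 1.3-fold lower number from compound 2 to compound 3 (0.11 log units; within the scatter), expected to sit within the scatter.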

Compound 3, half-maximal inhibitory concentration: 8900 nM
Compound 3: the middle estimate sits 2.2-fold (0.35 log units) above what was measured; measured number inside the range.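

In this assay, the aromatic ring on this side of the core responds to a change as small as one methyl, not only to an exchange of the whole ring: going from phenyl to 4-methylphenyl gives a 2.9-fold lower number from compound 2 to compound 3 (0.47 log units; beyond the scatter). Exchanging thiophen-2-yl for 4-methylphenyl gives an at least 28-fold lower number from compound 1 to compound 3 (1.44 log units; beyond the scatter), which extends the earlier finding on the ring exchange to a substituted phenyl. Compound 1 stands at a limit of the assay and not at a number, so this step gives only a lower bound on its size: the limit of > 250000 nM in this assay, at which 1 of the 3 values shown sits.

The compounds shown leave open whether the shift at this place, para to a large group, is particular to methyl or would also appear with a chloro, a methoxy or a longer chain such as ethyl or propyl. They also leave open how the number depends on the amine on the other phenyl ring, which all three compounds carry, and whether a replacement such as a hydroxyl or an amide there would keep the numbers seen so far.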